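Swapping a Chloroacetyl Cap for a Tosyl Cap

The source may hold more compounds than are shown below. What is called first, only, known or untested is meant among the compounds shown, and "the series" means these compounds.

Of the compounds shown here, two have been measured so far. Compound 1 `CC1=NN(C(=O)CN2CCN(C(=O)OC(C)(C)C)CC2)C(c2ccccc2O)C1` is tested in a functional assay on HepG2 cells (Homo sapiens) for cytotoxicity, read by MTT assay, with a stated time of 48 h (a lower number here means a stronger inhibitor, a higher number a weaker inhibitor), and gives 5000 nM. Compound 2 `O=C(CCl)N1N=C(c2cc3ccccc3oc2=O)CC1c1ccccc1` gives in this assay 2980 nM, the lowest of the two numbers, although the gap to compound 1 lies within the usual scatter, so the two cannot be ranked against each other. Compound 3 `Cc1ccc(S(=O)(=O)N2N=C(c3cc4ccccc4oc3=O)CC2c2ccccc2)cc1` has not been measured yet. It differs from compound 2 in one place: (4-methylphenyl)sulfonyl in place of (chloromethyl)carbonyl on an amine nitrogen in a ring. For the measured compounds named here, no measured pair shows what such an exchange does in this assay, so there is no direct guide. Going by the values given here, with only two measured compounds, both close together, the expected step of a 1.2-fold higher number from compound 2 to compound 3 (0.07 log units; within the scatter) is small, in no set direction, and not beyond the scatter. Compound 3 is therefore estimated at 3500 nM, with a range from 1000 nM to 12000 nM.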

Compound 3, half-maximal inhibitory concentration: "not active" (no number reported)
For compound 3 the study gives words and no number; no gap can be computed for the estimate.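

In this assay, for the compounds shown here, compound 3 is reported only in words, as "not active", with no number, and no step from compound 2 to compound 3 can be read. Nothing shown accounts for this result. The compounds shown leave open how large the change from (chloromethyl)carbonyl to (4-methylphenyl)sulfonyl is.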